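Oxazole-carboxamide piperazines: aryl swap at the piperazine nitrogen

The source may report more compounds than this note shows. Statements on the series, on what has been measured and on what is new or still open speak of the compounds shown alone.

Measured so far in a functional assay on HL-60 cells (Homo sapiens) for inhibition, read by MTT assay, with a stated time of 72 h; a higher number here means a weaker inhibitor, a lower number a stronger inhibitor:
- compound 1 `C=C(C)c1ccc(N2CCN(C(=O)c3oc(C)nc3-c3ccccc3)CC2)cc1`: "not active" (no number reported)
- compound 2 `Cc1cc(C)cc(N2CCN(C(=O)c3oc(C)nc3-c3ccccc3)CC2)c1`: 34.5 nM

Within the data shown here, compound 2 holds the only number in this assay ; compound 1 carries no number, only a report of no activity. Among the measured compounds shown here, nothing beyond these two entries is known, so no step between measured compounds can be stated.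

Compound 3 `Cc1nc(-c2ccccc2)c(C(=O)N2CCN(c3cccc(C#N)c3)CC2)o1` differs from compound 2 in one place: 3-cyanophenyl in place of 3,5-dimethylphenyl on an amine nitrogen in a ring. For the measured compounds named here, no measured pair shows what this exchange does in this assay. A moderate step is expected, in the direction of weaker inhibition, probably beyond the usual scatter but not large. Compound 3 is therefore estimated at 100 nM, with a range from 25 nM to 500 nM. The step of a 2.9-fold higher number from compound 2 to compound 3 (0.46 log units; beyond the scatter) is the expected size of that change, and it rests on compound 2 alone.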

Compound 3, half-maximal inhibitory concentration: 39.6 nM
Estimate against measurement, compound 3: 2.5-fold (0.40 log units) above, within the range that was stated.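

In this assay, among these compounds, 3-cyanophenyl in place of 3,5-dimethylphenyl on the amine nitrogen in the ring gives a 1.1-fold higher number from compound 2 to compound 3 (0.06 log units; within the scatter), the first readable step at this position. The two groups therefore stand level here, although only 3-cyanophenyl counts a hydrogen-bond acceptor, so a numerical value at this position does not depend on keeping 3,5-dimethylphenyl, while compound 1, with its own aryl group, is reported as "not active" (no number reported). No measurement available bears on why these two groups read alike.

Going by these compounds, it remains open whether this tolerance extends to other groups on the aryl ring, such as a carboxylic acid or an aminomethyl group, or to a cyclohexyl ring in place of the aryl ring. On these data alone, the contribution of the shared core is also open, since neither step touches it.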